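A few compounds are considered here, and "the series" means these few. Any claim that something is new, unique, unknown or untested is made for them only; others in the source may bear on it.

Measured so far:
- compound 1 `Cc1[nH]c2ccccc2c1C(c1ccccc1)c1cc2ccccc2o1`: 56500 nM
- compound 2 `Cc1[nH]c2ccccc2c1C(c1ccccc1)c1cc2cc(Cl)ccc2o1`: 47500 nM
- compound 3 `COc1ccc2oc(C(c3ccccc3)c3c(C)[nH]c4ccccc34)cc2c1`: > 100000 nM, which is a limit of the assay rather than a number

In a functional assay on SiHa cells (Homo sapiens) for cytotoxicity (on this read-out lower numbers stand for stronger inhibition and higher numbers for weaker inhibition), compound 1 holds the higher of the two plain numbers; its nearest neighbour is compound 2, with a 1.2-fold lower number from compound 1 to compound 2 (0.08 log units; within the scatter). Compound 4 `COc1ccc(C(c2cc3ccccc3o2)c2c(C)[nH]c3ccccc23)cc1` differs from compound 1 by methoxy in place of hydrogen on an aromatic carbon. Among the measured compounds shown here, two measured steps bear on this change, both placing a methoxy on a different ring: an at least 1.7-fold higher number from compound 1 to compound 3 (0.24 log units; that floor lies within the scatter) and an at least 2.1-fold higher number from compound 2 to compound 3 (0.32 log units; beyond the scatter). Compound 3 sits at the limit of > 100000 nM in this assay, at which 1 of the 3 values shown sits. On that basis compound 4 is expected to show inhibition similar to or weaker than compound 1, with a 1.3-fold higher number from compound 1 to compound 4 (0.12 log units; within the scatter). Compound 4 is therefore estimated at 75000 nM, within a range from 30000 nM to 180000 nM.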

Compound 4, half-maximal inhibitory concentration: > 100000 nM
Compound 4: no number, only a limit; the forecaster's own chance of this, stated with the estimate: 35%; at least 1.3-fold (0.12 log units) between middle value and limit.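

In this assay, compound 4 gives > 100000 nM, which is a limit of the assay and not a number. Replacing phenyl with 4-methoxyphenyl brings no gain here, though the step, an at least 1.7-fold higher number from compound 1 to compound 4 (0.24 log units; that floor lies within the scatter), does not by itself establish a real loss. Methoxy in this new place ends at the same limit as methoxy elsewhere on the core in compound 3: the limit of > 100000 nM in this assay, at which 2 of the 4 values shown sit.

On these data alone, how far compound 4 lies past the limit remains unknown. Also open, as far as these compounds go, is whether fluoro, an amine or a carboxylic acid in the same place would give a lower number.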